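This account rests on a few compounds, and the source may have more. Where it says the series, first, only, none or still open, it means among the compounds named here.

In a functional assay on NCI-H460 cells (Homo sapiens) for cytotoxicity, read by MTT assay, with a stated time of 72 h (a lower number here means a stronger inhibitor, a higher number a weaker inhibitor), compound 2 `O=c1[nH]/c(=C\c2c[nH]cn2)c(=O)[nH]/c1=C\c1cccc(Oc2ccc(F)cc2)c1` gives 479 nM and sits within the scatter of compound 3 `O=C(c1ccc(F)cc1)c1cccc(/C=c2\[nH]c(=O)/c(=C/c3c[nH]cn3)[nH]c2=O)c1` at 278 nM while compound 1 `CC(C)c1[nH]cnc1/C=c1\[nH]c(=O)/c(=C/c2cccc(C(=O)c3ccc(F)cc3)c2)[nH]c1=O` shows a far lower number at 3.2 nM in the same read-out. Compound 4 `O=c1[nH]/c(=C\c2ncc[nH]2)c(=O)[nH]/c1=C\c1cccc(Oc2ccc(F)cc2)c1` has the same atoms as compound 2, joined differently (1H-imidazol-2-yl in place of 1H-imidazol-4-yl on a double-bonded chain carbon bound to an aromatic carbon). Among the measured compounds shown here, no measured step moves the imidazole attachment, so the evidence is indirect. The step of a 1.7-fold lower number from compound 2 to compound 3 (0.24 log units; within the scatter) concerns the 4-fluorophenoxy group, not the imidazole, and says little here. The step of an 87-fold higher number from compound 1 to compound 3 (1.94 log units; beyond the scatter) is the only one that touches the imidazole, and its size shows that a change on this ring can matter. It involves loss of isopropyl, however, not a change of attachment, so it fixes no direction for compound 4. A small rise in this assay is therefore expected, probably not beyond the scatter, with a wide margin. The expected size is a 1.3-fold higher number from compound 2 to compound 4 (0.10 log units; within the scatter) on this reasoning. For compound 4 the estimated value is 600 nM (150 nM to 2500 nM).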

Compound 4, half-maximal inhibitory concentration: > 1000 nM
Compound 4: no number, only a limit; the forecaster's own chance of this, stated with the estimate: 8%; at least 1.6-fold (0.22 log units) between middle value and limit.
By their numbers in this assay, from the lowest: compound 1; then compounds 3 and 2 (each within the scatter of the next). At a limit, above all of these: compound 4.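

In this assay, the reading for compound 4 is a limit and not a number: the limit of > 1000 nM in this assay, at which 1 of the 4 values shown sits.

Changing only the imidazole attachment, with 1H-imidazol-2-yl in place of 1H-imidazol-4-yl, gives an at least 2.0-fold higher number from compound 2 to compound 4 (0.31 log units; beyond the scatter), so the way this ring is joined to the double-bonded chain carbon matters on its own. On these data alone, the earlier evidence on this ring, an 87-fold higher number from compound 1 to compound 3 (1.94 log units; beyond the scatter), involved the loss of isopropyl, whereas here the counted heavy atoms, donors and acceptors stay the same and only the attachment differs; the full size of the new step remains unknown.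

As far as these compounds go, it remains open whether an isopropyl group on the 1H-imidazol-2-yl ring would lower the number as it does on the 1H-imidazol-4-yl ring. From the compounds shown here alone, how a methyl group or a pyridine ring would read in this place is also open.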